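Bromo in place of phenyl on an aromatic carbon

The source may hold more compounds than are shown below. What is called first, only, known or untested is meant among the compounds shown, and "the series" means these compounds.

Among the measured compounds shown here, in a functional assay (strain AB) with Danio rerio as the target, read by microscopy, with a stated time of 1 h (on this read-out higher numbers stand for an effect only at larger amounts of compound and lower numbers for an effect already at smaller amounts), compound 1 `CCN1CCc2c(sc(NC(=O)Nc3ccc(Cl)cc3)c2C(N)=O)C1` gives 3120 nM and compound 2 `CCN1CCc2c(sc(NC(=O)Nc3ccc(-c4ccccc4)cc3)c2C(N)=O)C1` gives 3390 nM as the only two numbers so far. These two values lie within the scatter of each other, so compound 2 has no rank of its own on the numbers shown. Compound 3 `CCN1CCc2c(sc(NC(=O)Nc3ccc(Br)cc3)c2C(N)=O)C1` keeps the shared core of compound 2 and differs from it at one place, on an aromatic carbon of a six-membered aromatic ring of carbon only and para to a large group. The difference is bromo in place of phenyl on an aromatic carbon and amounts to bromo in place of phenyl. For the measured compounds named here, only one measured step bears on this place: phenyl in place of chloro gave a 1.1-fold higher number from compound 1 to compound 2 (0.04 log units; within the scatter) and so showed nothing beyond the scatter. Bromo itself has no number here, and the expectation rests on that single step. The estimated step is a 1.1-fold lower number from compound 2 to compound 3 (0.03 log units; within the scatter) and is expected to stay within the scatter, with no direction favoured. Compound 3 is therefore estimated at 3200 nM within a range of 1600 nM to 6400 nM on this read-out.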

Compound 3, half-maximal effective concentration: 3130 nM
Compound 3: the middle estimate sits 1.0-fold (0.01 log units) above what was measured; measured number inside the range.
By their numbers in this assay, from the lowest: compounds 1, 3 and 2 (each within the scatter of the next).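

In this assay, the change at this place, on an aromatic carbon of a six-membered aromatic ring of carbon only and para to a large group, gives a 1.1-fold lower number from compound 2 to compound 3 (0.03 log units; within the scatter), and bromo in place of chloro gives a 1.0-fold higher number from compound 1 to compound 3 (0.00 log units; within the scatter). The position now holds three groups whose numbers all lie within the scatter of one another: chloro, bromo and phenyl, the last with 6 heavy atoms and a ring against the single heavy atom of bromo, so this read-out separates none of them, and what held for one pair of groups now holds across a second halogen as well. No measurement at hand offers an account of why these numbers stay together.

Bromo and phenyl both count 0 hydrogen-bond donors and 0 hydrogen-bond acceptors, so it remains open whether a group such as an amine or a carboxylic acid at this place would move the number beyond the scatter. The ethyl group and the carboxamide of the shared core are also the same throughout, which leaves open what a change at either of them would do.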